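One Added Methyl in a Growth Inhibition Series

The source may report more compounds than this note shows. Statements on the series, on what has been measured and on what is new or still open speak of the compounds shown alone.

Measured so far:
- compound 1 (`Cc1cc(C)c2c(O)cc(-c3cccc4ccccc34)nc2n1`) gives 759 nM
- compound 2 (`Cc1cnc2[nH]c(-c3cccc(Cl)c3)cc(=O)c2c1`) gives > 100000 nM as a limit
- compound 3 (`Cc1ccnc2nc(-c3ccc4ccccc4c3)cc(O)c12`) gives 1380 nM

In a functional assay on PC-3 cells (Homo sapiens) for antiproliferative activity (on this read-out lower numbers stand for stronger inhibition of growth and higher numbers for weaker inhibition of growth), compound 3 stands at 1380 nM and lies within the scatter of compound 1 at 759 nM on the same read-out. For compound 2 the entry > 100000 nM is a limit and not a number.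

Compound 4 (`Cc1cc(C)c2c(O)cc(-c3ccc4ccccc4c3)nc2n1`) is reached from compound 3 by one change, methyl in place of hydrogen on an aromatic carbon with methyl in place of hydrogen on an aromatic carbon, next to the ring nitrogen. Going by the values given here, no measured pair shows this change on its own. Among the compounds with values here, the only guide is how close compound 1 at 759 nM sits to compound 3 at 1380 nM and so no step beyond the scatter is expected in this assay in either direction. The estimated step of a 1.5-fold lower number from compound 3 to compound 4 (0.19 log units; within the scatter) stays within the scatter. Compound 4 is expected at 900 nM with an estimated range from 280 nM to 3500 nM for its measurement.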

Compound 4, concentration for 50% growth inhibition: 5500 nM
Compound 4: middle estimate off by 6.1-fold (0.79 log units), on the low side; measured number above the stated range.
By their numbers in this assay, from the lowest: compounds 1 and 3 (each within the scatter of the next); then compound 4. At a limit, above all of these: compound 2.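

In this assay, going by these compounds alone, the earlier compounds gave no pair that isolated this change. The first such pair shows that methyl in place of hydrogen on this aromatic carbon, next to the ring nitrogen, weakens growth inhibition, with a 4.0-fold higher number from compound 3 to compound 4 (0.60 log units; beyond the scatter) beyond the scatter. A single added carbon at this position is therefore enough to shift the read-out, although compound 1, which also carries this methyl, gives 759 nM. Nothing at hand accounts for the step.

The compounds shown leave open whether the same change would act alike with the other attachment seen in compound 1, as this step comes from one pair only. They also leave open how an amine, a methoxy group or a longer chain such as ethyl would read at this position.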